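This account rests on a few compounds, and the source may have more. Where it says the series, first, only, none or still open, it means among the compounds named here.

Working notes on the series, read in a functional assay on HCT-116 cells (Homo sapiens) for inhibition, read by MTT assay, with a stated time of 48 h; on this read-out lower numbers stand for stronger inhibition and higher numbers for weaker inhibition. Compound 1 `C[Se]c1ccc(N(C)c2nc(C3CC3)nc3ccccc23)cc1` gives 15 nM and compound 3 `Cc1nc(N(C)c2ccc([Se]C#N)c(Cl)c2)c2ccccc2n1` gives 12 nM, two values that are not separated beyond the scatter. Compound 2 `COc1ccc(N(C)c2nc(C)nc3ccccc23)cc1C(=O)OCCC[Se]C#N` gives 720 nM, the highest number of the three and so the weakest inhibitor so far, with a gap to both other compounds that lies well beyond the scatter.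

The next compound is compound 4 `COc1ccc(N(C)c2nc(C)nc3ccccc23)cc1[Se]C#N`. Its change from compound 2 is a group of 3 heavy atoms (1 carbon, 1 nitrogen, 1 selenium; no ring) in place of a group of 9 heavy atoms (5 carbon, 1 nitrogen, 2 oxygen, 1 selenium; no ring), on an aromatic carbon, and it sits on an aromatic carbon of a six-membered aromatic ring of carbon only, ortho to a methoxy group. For the measured compounds named here, no measured pair differs in one place only, so the size of this step has no direct precedent.

The nearest guide is compound 3, which also carries the incoming group on an aromatic carbon and gives 12 nM. It differs from compound 4 in other places too, so that value can only be carried over loosely. A large fall in the number, beyond the scatter, is expected, and the estimated step is an 18-fold lower number from compound 2 to compound 4 (1.26 log units; beyond the scatter). For compound 4 the estimate is 40 nM, with an expected range of 8 nM to 200 nM.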

Compound 4, half-maximal inhibitory concentration: 34 nM
Estimate against measurement, compound 4: 1.2-fold (0.07 log units) above, within the range that was stated.
By their numbers in this assay, from the lowest: compounds 3 and 1 (each within the scatter of the next); then compound 4; then compound 2.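

In this assay, for the compounds shown here, the first change confined to one place is a large one, a 21-fold lower number from compound 2 to compound 4 (1.33 log units; beyond the scatter), so the group carried on this aromatic carbon, ortho to a methoxy group, has a strong bearing on the read-out. Both the group that leaves and the group that enters hold selenium, a nitrogen and a triple bond, so the presence of these atoms alone does not set the number in this pair; the pair differs in the size of the group, with the group of 9 heavy atoms also carrying a double bond and 3 hydrogen-bond acceptors against 1 for the group of 3 heavy atoms. Nothing available here gives a measured reason for the size of this step.

A single pair cannot tell which part of the group of 9 heavy atoms accounts for the higher number of compound 2, since size, the double bond and the acceptor count all change together. Also open, from the compounds shown here alone, is how this aromatic carbon responds to groups without selenium, such as an amine or a carboxylic acid, and whether a chain of intermediate length would give a number between those of the two compounds.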